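Methoxy in place of fluoro on an aromatic carbon

The source may report more compounds than this note shows. Statements on the series, on what has been measured and on what is new or still open speak of the compounds shown alone.

In a functional assay on MDA-MB-436 cells (Homo sapiens) for antiproliferative activity, read by MTT assay, with a stated time of 48 h (on this read-out higher numbers stand for weaker inhibition and lower numbers for stronger inhibition), compound 1 (`COc1ccc(NC(=O)N2CCN(c3ncnc4sc(-c5ccc(N6CCN(C)CC6)cc5)cc34)CC2)cc1`) gives 30100 nM and compound 2 (`CN1CCN(c2ccc(-c3cc4c(N5CCN(C(=O)Nc6ccccc6F)CC5)ncnc4s3)cc2)CC1`) gives 14300 nM as the lower of the two numbers, which makes it the stronger inhibitor of this pair. Compound 3 (`COc1ccccc1NC(=O)N1CCN(c2ncnc3sc(-c4ccc(N5CCN(C)CC5)cc4)cc23)CC1`) has not been measured yet. It differs from compound 2 by one change: methoxy in place of fluoro on an aromatic carbon, ortho to a large group (methoxy in place of fluoro on an aromatic carbon). Among the measured compounds shown here, only one measured step bears on this, the one that brings in the 2-fluorophenyl group, and it is modest: a 2.1-fold lower number from compound 1 to compound 2 (0.32 log units; beyond the scatter) on that ring. Compound 1 carries a methoxy group too, but not where compound 2 has its fluoro, so it is only a loose guide. A step of that small size, and the 30100 nM of compound 1 with its methoxy group, suggest a slight lean towards a higher number. The expected change is a 1.4-fold higher number from compound 2 to compound 3 (0.15 log units; within the scatter) and so no clear shift is expected. In this assay compound 3 is expected at 20000 nM with an estimated range from 9000 nM to 45000 nM as its two ends.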

Compound 3, half-maximal inhibitory concentration: 26300 nM
The estimate for compound 3 lay 1.3-fold (0.12 log units) below the measured number; low and high end bracket the measured number.
By their numbers in this assay, from the lowest: compounds 2, 3 and 1 (each within the scatter of the next, the first and the last beyond it).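

In this assay, putting methoxy in place of fluoro on this aromatic carbon, ortho to a large group, gives a 1.8-fold higher number from compound 2 to compound 3 (0.26 log units; within the scatter), so at this place the two groups cannot be told apart by this read-out. Among the compounds shown here, the methoxy group's place on the ring is equally unreadable: 2-methoxyphenyl in place of 4-methoxyphenyl gives a 1.1-fold lower number from compound 1 to compound 3 (0.06 log units; within the scatter), which means that compound 3 lies within the scatter of both of its neighbours and that the earlier 2.1-fold lower number from compound 1 to compound 2 (0.32 log units; beyond the scatter), the only step here beyond the scatter, cannot be pinned on either the change of group or the change of place alone. No measurement available here offers an explanation for these small differences.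

The compounds shown leave open whether a different group on this ring carbon, such as an amine, a carboxylic acid or a longer chain like ethoxy, would move the number clearly beyond the scatter. They also leave open how a plain phenyl ring, with only hydrogen at this place, would compare with the fluoro and methoxy compounds.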